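This account rests on a few compounds, and the source may have more. Where it says the series, first, only, none or still open, it means among the compounds named here.

Measured so far in a functional assay on cells for antagonist activity at Free fatty acid receptor 1 (Homo sapiens), read by TR-FRET and inositol phosphate accumulation, with a stated time of 2 h; on this read-out lower numbers stand for stronger inhibition and higher numbers for weaker inhibition:
compound 1 `OC1CN(c2cc(COc3ccc(F)c(F)c3F)nc(-c3ccccn3)n2)C1`, 3160 nM
compound 2 `CC1(CS(C)(=O)=O)CN(c2cc(COc3ccc(F)c(F)c3F)nc(-c3ccccn3)n2)C1`, 6310 nM

Going by the values given here, compound 2 carries the higher of the two numbers, but its only neighbour is compound 1, and the step of a 2.0-fold higher number from compound 1 to compound 2 (0.30 log units; within the scatter) lies within the scatter; on these numbers the two compounds stand level rather than in any order.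

The next compound, compound 3 `CC1(C#N)CN(c2cc(COc3ccc(F)c(F)c3F)nc(-c3ccccn3)n2)C1`, has not been measured in this assay. It differs from compound 2 in one place: cyano in place of (methylsulfonyl)methyl on a saturated ring carbon. Among the compounds with values here, only one measured step bears on this exchange, and it concerns the same saturated ring carbon of the four-membered non-aromatic ring with 1 nitrogen: there, a 2.0-fold higher number from compound 1 to compound 2 (0.30 log units; within the scatter), within the scatter. Within the data shown here, nothing among the measured compounds separates one substituent on that carbon from another, so for compound 3 the expectation in this assay is no step beyond the scatter, a 1.3-fold lower number from compound 2 to compound 3 (0.10 log units; within the scatter). Compound 3 is accordingly estimated at 5000 nM, with a range from 1800 nM to 14000 nM.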

Compound 3, half-maximal inhibitory concentration: 158 nM
For compound 3 the middle estimate is 32-fold (1.50 log units) above the measured one; measured number outside the range, below it.
By their numbers in this assay, from the lowest: compound 3; then compounds 1 and 2 (each within the scatter of the next).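

In this assay, the saturated ring carbon two ring bonds from the ring nitrogen does separate substituents: cyano in place of (methylsulfonyl)methyl gives a 40-fold lower number from compound 2 to compound 3 (1.60 log units; beyond the scatter), whereas the earlier pair showed no step beyond the scatter. The 3-cyano-3-methylazetidin-1-yl group also stands clear of 3-hydroxyazetidin-1-yl, with a 20-fold lower number from compound 1 to compound 3 (1.30 log units; beyond the scatter), so compound 3 is set apart from compound 1 and compound 2 by steps beyond the scatter, and the level standing of those two no longer describes this position as a whole. No measurement at hand accounts for what the cyano group does at this carbon.

On these data alone, it stays open whether a cyanomethyl, a carboxylic acid or an amine on that same carbon would match compound 3 at 158 nM, or whether the step belongs to cyano alone. Also open, as far as these compounds go, is the part played by the methyl on that carbon, which compound 2 and compound 3 share, and whether an ethyl or a plain hydrogen in its place would change the number.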